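Series notes: benzyl in place of methyl on the aromatic nitrogen

A few compounds are considered here, and "the series" means these few. Any claim that something is new, unique, unknown or untested is made for them only; others in the source may bear on it.

Of the compounds shown here, two have been measured in a functional assay on the whole organism (strain albino) for inhibition, with Rattus norvegicus as the target, read by paw edema, with stated times of 1 h and 0.5 h, at a dose of 100 mg/kg by the oral route; on this read-out higher numbers stand for more inhibition at the one dose given (going by the name of the read-out) and lower numbers for less inhibition. Compound 1 `N#Cc1c(-c2ccccc2)nc(SCC(=O)Nn2c(COc3ccc(Cl)cc3Cl)nc3ccccc3c2=O)[nH]c1=O` gives 80.8%. Among the measured compounds shown here, compound 2 `Cn1c(SCC(=O)Nn2c(COc3ccc(Cl)cc3Cl)nc3ccccc3c2=O)nc(-c2ccccc2)c(C#N)c1=O` gives 51.9%, the lower of the two numbers, and the only step measured so far, a number 28.9 percentage points lower from compound 1 to compound 2 (beyond the scatter), is the change that separates them. Compound 3 `N#Cc1c(-c2ccccc2)nc(SCC(=O)Nn2c(COc3ccc(Cl)cc3Cl)nc3ccccc3c2=O)n(Cc2ccccc2)c1=O` is not yet measured; it differs from compound 2 by phenyl in place of hydrogen on a saturated chain carbon bound to an aromatic nitrogen. For the measured compounds named here, no measured step covers this change directly. Going by the values given here, the one step available shows that replacing the hydrogen on the aromatic nitrogen with methyl cost inhibition in this assay; whether a larger group at the same position costs more or recovers some of it cannot be read from these two numbers. The expected step is therefore a number 6.9 percentage points lower from compound 2 to compound 3 (within the scatter), within or only slightly beyond the scatter. Compound 3 is estimated at 45%, with a range from 25% to 65%.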

Compound 3, a percentage reported as inhibition, in the whole organism at one dose (the size of the read-out at that dose, not a potency): 76%
For compound 3 the middle estimate is 31 percentage points below the measured one; the whole stated range lies below it.
By their numbers in this assay, from the lowest: compound 2; then compounds 3 and 1 (each within the scatter of the next).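

In this assay the loss seen with methyl on the aromatic nitrogen does not extend to every group at this position: methyl to benzyl gives a number 24.1 percentage points higher from compound 2 to compound 3 (beyond the scatter) and so reverses most of that loss. Set against the hydrogen on the same nitrogen, benzyl gives a number 4.8 percentage points lower from compound 1 to compound 3 (within the scatter) and shows that this nitrogen can carry a substituent with no loss that stands out from the scatter. The response to size here is therefore not a steady decline from hydrogen through methyl to benzyl, at least across these three compounds. No evidence at hand bears on the difference between the methyl and benzyl results.

From the compounds shown here alone, whether the phenyl ring itself matters or any larger group would serve stays open, and an ethyl group or a longer alkyl chain on this nitrogen would separate the two. The compounds shown also leave open how a chlorine or a methoxy group on the benzyl ring would read.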